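Fluoro for trifluoromethyl on the aryl of compound 1

The compounds below may be only part of what the source reports. "The series", "measured", "known", "first", "only" and "open" are said of these compounds alone.

Of the compounds shown here, three of the shared core have been measured in a functional assay on Huh-7 cells (Homo sapiens) for inhibition, read by sulforhodamine B assay, with a stated time of 72 h; a higher number here means a weaker inhibitor, a lower number a stronger inhibitor. Compound 1 `CC(c1ccc(-c2ccccc2)c(F)c1)c1nnc2n1N=C(c1ccc(C(F)(F)F)cc1)CS2` gives 9400 nM. Compound 3 `CC(C)Cc1ccc(C(C)c2nnc3n2N=C(c2ccc(F)cc2)CS3)cc1` gives 7800 nM, and compound 2 `COc1ccc2cc(C(C)c3nnc4n3N=C(c3ccc([N+](=O)[O-])cc3)CS4)ccc2c1` gives 14700 nM. The three numbers lie within the usual scatter of one another, so compound 1 stands level with both.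

Compound 4 `CC(c1ccc(-c2ccccc2)c(F)c1)c1nnc2n1N=C(c1ccc(F)cc1)CS2` differs from compound 1 in one place: fluoro in place of trifluoromethyl on an aromatic carbon. Compound 3 carries the same 4-fluorophenyl and gives 7800 nM, a number level with compound 1. The expected step from compound 1 to compound 4, a 1.0-fold lower number from compound 1 to compound 4 (0.02 log units; within the scatter), is therefore none beyond the scatter. Compound 4 is estimated at 9000 nM in this assay. The expected range for compound 4 runs from 4500 nM to 18000 nM.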

Compound 4, half-maximal inhibitory concentration: 4900 nM
Estimate against measurement, compound 4: 1.8-fold (0.26 log units) above; low and high end bracket the measured number.
By their numbers in this assay, from the lowest: compounds 4, 3, 1 and 2 (each within the scatter of the next, the first and the last beyond it).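

Among these compounds, the first matched pair at this position reads a 1.9-fold lower number from compound 1 to compound 4 (0.28 log units; within the scatter) in this assay, so the two compounds stand level. With the fluorinated biphenyl side of compound 1 held fixed, the 4-(trifluoromethyl)phenyl and 4-fluorophenyl groups cannot be told apart here, although fluoro has fewer heavy atoms. No data on hand bear on any cause for this result.

From the compounds shown here alone, whether an amine or a carboxylic acid on this aromatic carbon would give a step beyond the scatter remains open. So does whether this level reading holds with other groups on the far side of the shared core.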